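This account rests on a few compounds, and the source may have more. Where it says the series, first, only, none or still open, it means among the compounds named here.

Compound 1, with the structure `COc1ccccc1/C=C/C(=O)c1ccc(OCCn2cc(CN3C(=O)/C=C/C(C)(C)C/C=C(\C)CC/C=C/3C)nn2)cc1O`, and compound 2, with the structure `COc1cc(/C=C/C(=O)c2ccc(OCCn3cc(CN4C(=O)/C=C/C(C)(C)C/C=C(\C)CC/C=C/4C)nn3)cc2O)cc(OC)c1OC`, share one core, while compound 3, with the structure `COc1ccccc1/C=C/C(=O)c1ccc(OCCCN2C(=O)/C=C/C(C)(C)C/C=C(\C)CC/C=C/2C)cc1`, and the not yet measured compound 4, with the structure `COc1cc(/C=C/C(=O)c2ccc(OCCCN3C(=O)/C=C/C(C)(C)C/C=C(\C)CC/C=C/3C)cc2)cc(OC)c1OC`, share another. The difference between the two cores is not broken down here. In a functional assay on P338 cells (Mus musculus) for antiproliferative activity (on this read-out higher numbers stand for weaker inhibition and lower numbers for stronger inhibition), compound 1 gives 1.1 ug/mL, and in this assay compound 2 gives 0.89 ug/mL. The change between them, (3,4,5-trimethoxyphenyl in place of 2-methoxyphenyl on a double-bonded chain carbon bound to a double-bonded chain carbon), made a step of a 1.2-fold lower number from compound 1 to compound 2 (0.09 log units; within the scatter). In this assay compound 3 gives 0.83 ug/mL, a number within the scatter of both compound 1 and compound 2. Compound 4 carries the same change on the other core: 3,4,5-trimethoxyphenyl in place of 2-methoxyphenyl on a double-bonded chain carbon bound to a double-bonded chain carbon. Because the earlier step of a 1.2-fold lower number from compound 1 to compound 2 (0.09 log units; within the scatter) was small, a step of about the same size, a 1.2-fold lower number from compound 3 to compound 4 (0.07 log units; within the scatter), is expected from compound 3 to compound 4 in this assay. On that basis compound 4 is estimated to give 0.7 ug/mL in this assay, most likely between 0.35 ug/mL and 1.4 ug/mL.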

Compound 4, half-maximal inhibitory concentration: 0.77 ug/mL
Estimate against measurement, compound 4: 1.1-fold (0.04 log units) below; the measured number falls inside the stated range.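

In this assay, putting 3,4,5-trimethoxyphenyl in place of 2-methoxyphenyl on the second core gave a 1.1-fold lower number from compound 3 to compound 4 (0.03 log units; within the scatter). Set beside the same change on the first core, the two steps agree: the same change on two cores in this assay, a 1.2-fold lower number (0.09 log units; within the scatter) from compound 1 to compound 2 and a 1.1-fold lower number (0.03 log units; within the scatter) from compound 3 to compound 4, 1.1-fold (0.06 log units) apart, within the scatter of two such steps This shows that the change behaves alike on these two cores, leaving the number within the scatter on each, but it does not show a real gain on either core, and with no sizeable step to carry over, it is only a weak test of whether a larger effect would transfer from one core to another.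

The compounds shown carry only these two methoxy-bearing phenyl groups on a double-bonded chain carbon bound to a double-bonded chain carbon, so it remains open whether a phenyl group bearing an amine or a carboxylic acid there would move the number beyond the scatter. Going by these compounds, whether the same agreement would hold on a core with a longer chain also remains open.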